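Removing an ethyl group from compound 3

The source may hold more compounds than are shown below. What is called first, only, known or untested is meant among the compounds shown, and "the series" means these compounds.

Measured so far:
Compound 1 `O=C1c2ccc(Cl)cc2CN1c1cccnc1`: 76.5 mL/min/kg
Compound 2 `CC1c2cc(Cl)ccc2C(=O)N1c1cccnc1`: 66.5 mL/min/kg
Compound 3 `CCC(=O)N[C@@H]1CCCc2c1cncc2N1C(=O)c2ccc(Cl)cc2[C@@H]1CC`: < 20.2 mL/min/kg (a limit of the assay)

In an ADME assay on microsomes from liver (Mus musculus) for metabolic stability, read by LC-MS, using NADPH, with stated times of 10 min and 30 min (a higher number here means faster removal of the compound, a lower number slower removal), compound 3 gives < 20.2 mL/min/kg, which is a limit of the assay and not a number. Within the data shown here, it stands at the low end of the three compounds measured so far.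

Compound 4 `CCC(=O)N[C@@H]1CCCc2c1cncc2N1Cc2cc(Cl)ccc2C1=O` has not yet been measured. It carries hydrogen in place of ethyl on a saturated ring carbon, next to the ring nitrogen: hydrogen in place of ethyl on a saturated ring carbon.

Among the measured compounds shown here, only one measured step resembles this change. It is a 1.2-fold lower number from compound 1 to compound 2 (0.06 log units; within the scatter), with methyl in place of hydrogen on a saturated ring carbon, and it lies within the scatter. That step adds a group where compound 4 loses one, and it was measured on smaller molecules, so it is only a rough guide. It gives no reason to expect a change beyond the scatter, and any small shift would be expected toward a higher number in this assay.

The expected change is an at least 1.2-fold higher number from compound 3 to compound 4 (0.09 log units; that floor lies within the scatter).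

For compound 4 the estimate is 25 mL/min/kg, with an expected range of 14 mL/min/kg to 50 mL/min/kg.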

Compound 4, clearance: < 20.2 mL/min/kg
Compound 4 was reported as a limit (the forecaster's own chance of this, stated with the estimate: 45%); at least 1.2-fold (0.09 log units) between middle value and limit.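

The step from compound 3 to compound 4, hydrogen in place of ethyl on a saturated ring carbon, cannot be read in this assay, because both compounds sit at a limit of the assay and not at a number: the limit of < 20.2 mL/min/kg in this assay, at which 2 of the 4 values shown sit.

The compounds shown leave open the actual clearance of compound 3 and compound 4, and so whether this swap changes it at all.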